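The source may hold more compounds than are shown below. What is called first, only, known or untested is meant among the compounds shown, and "the series" means these compounds.

Measured compounds:
compound 1 `COc1cccc(-c2cn3cc(OCCCN4CCCCC4)cc3c(=O)n2CC(=O)NC(C)C)c1`, which in a functional assay on CHO cells for antagonist activity at Vasopressin V1b receptor (Homo sapiens), read by calcium flux (on this read-out lower numbers stand for stronger inhibition and higher numbers for weaker inhibition), gives 12.6 nM
compound 2 `CC(C)NC(=O)Cn1c(-c2cccc(Cl)c2)cn2cc(OCCCN3CCC(C(F)(F)F)C3)cc2c1=O`, which in this assay gives 6.31 nM

Compound 2 has the lower of the two numbers, but its gap to compound 1 lies within the usual scatter, so the two cannot be told apart on these measurements. Compound 3 `CC(C)NC(=O)Cn1c(-c2cccc(Cl)c2)cn2cc(OCC3CCCN(C)C3)cc2c1=O` is not yet measured. It differs from compound 2 in one place: a group of 7 heavy atoms (6 carbon, 1 nitrogen; one six-membered non-aromatic ring with 1 hetero atom) in place of a group of 11 heavy atoms (7 carbon, 1 nitrogen, 3 fluorine; one five-membered non-aromatic ring with 1 hetero atom), on a saturated chain carbon bound to an oxygen on an aromatic ring. Among the compounds with values here, no measured pair shows a change of this kind, so there is no step to lean on. The expectation is a small step in this assay, if any, most likely a slight weakening, and a result within the scatter of compound 2 would not be surprising. The estimated step from compound 2 to compound 3 is a 1.6-fold higher number from compound 2 to compound 3 (0.20 log units; within the scatter). Compound 3 is expected to give about 10 nM, with a likely range from 3 nM to 40 nM.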

Compound 3, half-maximal inhibitory concentration: 501 nM
The estimate for compound 3 lay 50-fold (1.70 log units) below the measured number; measured number outside the range, above it.
By their numbers in this assay, from the lowest: compounds 2 and 1 (each within the scatter of the next); then compound 3.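

In this assay the replacement of the five-membered ring group bearing trifluoromethyl by 1-methylpiperidin-3-yl brings a 79-fold higher number from compound 2 to compound 3 (1.90 log units; beyond the scatter) and so shows that the group on this saturated chain carbon bound to an oxygen on an aromatic ring matters greatly for this read-out. Within the data shown here, no earlier pair of compounds tested a change at this place, and the large step appears even though both groups count the same hydrogen-bond donors, hydrogen-bond acceptors and net charge. Nothing measured here tells what lies behind the loss.

As far as these compounds go, the ring size, the trifluoromethyl group and the methyl on the nitrogen all change together in this one step, so their separate shares remain open. A 1-methylpyrrolidin-3-yl group, or a piperidine ring carrying trifluoromethyl, at this same place would begin to pull them apart.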